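The compounds below may be only part of what the source reports. "The series", "measured", "known", "first", "only" and "open" are said of these compounds alone.

Compound 1 `CCC(C)Oc1ccc(C(O)C2OC(=O)c3c(OC)cc(OC)cc32)cc1` gives > 40000 nM in an ADME assay on RAW264.7 cells (Mus musculus) for cytotoxicity, read by MTT assay, with a stated time of 24 h, in the absence of a further agent (on this read-out higher numbers stand for weaker inhibition and lower numbers for stronger inhibition), a limit of the assay.
Compound 2 `COCCOc1ccc(C(O)C2OC(=O)c3c(OC)cc(OC)cc32)cc1` gives > 40000 nM in this assay, also a limit.

Within the data shown here, the one step between them, a step that the two limits leave unreadable from compound 1 to compound 2, is not readable; both values are limits. Compound 1 therefore stands only at the limit of > 40000 nM in this assay, at which 2 of the 2 values shown sit. Compound 3 `COc1cc(OC)c2c(c1)C(C(O)c1ccc(OCc3ccc(C#N)cc3)cc1)OC2=O` differs from compound 1 by 4-cyanobenzyl in place of sec-butyl on an oxygen on an aromatic ring. With no readable step to draw on, no change beyond the scatter is expected in this assay from compound 1 to compound 3, and a further limit is the likely outcome. The expected step is a step that the limit leaves unreadable from compound 1 to compound 3. Compound 3 is estimated at 60000 nM, between 20000 nM and 200000 nM.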

Compound 3, half-maximal inhibitory concentration: > 40000 nM
Compound 3 gave a limit, no number; the forecaster's own chance of this, stated with the estimate: 85%; the middle value lies beyond the limit too.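

Among these compounds, compound 3 also gives only a limit, so no step among compound 1, compound 2 and compound 3 can be read. The compounds shown leave open at what concentration any of them would reach half-maximal inhibition in this assay, and whether the different groups on the oxygen change that concentration.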